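A few compounds are considered here, and "the series" means these few. Any claim that something is new, unique, unknown or untested is made for them only; others in the source may bear on it.

Compound 1 `COc1ccc(-c2cc(/C=C/C(=O)c3ccc(N)cc3)[nH]n2)cc1`: 92%
Compound 2 `COc1cc(-c2cc(/C=C/C(=O)c3ccc(Cl)c(Cl)c3)[nH]n2)cc(OC)c1OC`: 92%
Compound 3 `COc1cc(-c2cc(/C=C/C(=O)c3ccc(F)c(F)c3)[nH]n2)cc(OC)c1OC`: 92%

In a functional assay on OVCAR-5 cells (Homo sapiens) for cytotoxicity, read by sulforhodamine B assay, with a stated time of 48 h, tested at 1 uM (a lower number here means a stronger effect, a higher number a weaker effect of the compound at the concentration tested), compound 1 gives 92%, level with compound 2 at 92% and with compound 3 at 92%. For the measured compounds named here, the single measured step, no change at the digits printed from compound 2 to compound 3 (within the scatter), concerns the ring on the carbonyl carbon and lies away from the place changed here. Compound 4 `COc1ccc(-c2cc(/C=C/C(=O)c3ccc(N)cc3)[nH]n2)cc1OC` differs from compound 1 by methoxy in place of hydrogen on an aromatic carbon. Going by the values given here, no measured step touches this position, but compounds 2 and 3, which carry three methoxy groups on the ring that bears the pyrazole, sit at the same level as compound 1. The expected step is therefore a number 2 percentage points lower from compound 1 to compound 4 (within the scatter), nothing beyond the scatter. Compound 4 is estimated at 90%, with a range from 78% to 100%.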

Compound 4, a percentage reported as activity, at one concentration (the size of the read-out at that concentration, not a potency): 94%
The estimate for compound 4 lay 4 percentage points below the measured number; the measured number falls inside the stated range.
By their numbers in this assay, from the lowest: compounds 1, 2, 3 and 4 (each within the scatter of the next).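

Methoxy in place of hydrogen on an aromatic carbon, ortho to a methoxy group, gives in this assay a number 2 percentage points higher from compound 1 to compound 4 (within the scatter), the first step read directly at this position. At this single concentration, adding this group to the core of compound 1 therefore moves the read-out by no more than the scatter. No evidence on why this is so is available. As far as these compounds go, whether an amine, a hydroxyl or a longer chain such as ethoxy at this position would give a step beyond the scatter stays open. So does whether any of these compounds differ at another concentration.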